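Swapping ethynyl for 3-methyl-1,2-oxazol-5-yl on the side chain

The source may hold more compounds than are shown below. What is called first, only, known or untested is meant among the compounds shown, and "the series" means these compounds.

For the measured compounds named here, in a functional assay on SNB-19 cells (Homo sapiens) for inhibition, read by MTT assay, with a stated time of 7 days (on this read-out lower numbers stand for stronger inhibition of growth and higher numbers for weaker inhibition of growth), compound 1 `C#CCn1nnc2c(C(N)=O)ncn2c1=O` gives 35600 nM as the only exact number so far. Compound 2 `COc1ccc(Cn2nnc3c(C(N)=O)ncn3c2=O)cc1`, which also carries an aromatic ring on the saturated chain carbon, gives > 50000 nM and this is a limit of the assay, not a number. Going by the values given here, with one number and one limit, there is no measured step to serve as a guide.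

Compound 3 `Cc1cc(Cn2nnc3c(C(N)=O)ncn3c2=O)on1` differs from compound 1 by 3-methyl-1,2-oxazol-5-yl in place of ethynyl on a saturated chain carbon bound to an aromatic nitrogen, with 3-methyl-1,2-oxazol-5-yl in place of ethynyl on a saturated chain carbon bound to an aromatic nitrogen. Given that compound 2 reached only (the limit of > 50000 nM in this assay, at which 1 of the 2 values shown sits), a small shift toward weaker inhibition of growth seems likely, perhaps no larger than the usual scatter. The expected change is a 1.3-fold higher number from compound 1 to compound 3 (0.10 log units; within the scatter) in this estimate. For compound 3 the estimated value is 45000 nM, with an expected range from 22000 nM to 90000 nM.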

Compound 3, concentration for 50% growth inhibition: > 50000 nM
Compound 3: only a limit was reported; the forecaster's own chance of this, stated with the estimate: 50%; middle value at least 1.1-fold (0.04 log units) away from the limit.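

Replacing ethynyl with 3-methyl-1,2-oxazol-5-yl on a saturated chain carbon bound to an aromatic nitrogen gives, in this assay, an at least 1.4-fold higher number from compound 1 to compound 3 (0.14 log units; that floor lies within the scatter). For the compounds shown here, this is the first measured one-place change at this position, but it sets only a floor, and that floor does not separate the change from ordinary assay scatter. The value of compound 3 is a limit of the assay and not a number, so the true size of the step stays unknown, and the limit is a common result in this small set: the limit of > 50000 nM in this assay, at which 2 of the 3 values shown sit.

The compounds shown leave open whether any group at this place can give clearly stronger inhibition of growth than ethynyl. A saturated propyl chain would test whether the triple bond matters, while a chain ending in an amine or a carboxylic acid would probe a quite different kind of end group.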